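The compounds below may be only part of what the source reports. "The series", "measured", "known", "first", "only" and "open" are said of these compounds alone.

Compound 1 `COc1cc(CNc2nc3c(N)ncnc3n2[C@@H]2O[C@H](CO)[C@@H](O)[C@H]2O)ccc1-c1ccccc1`: 1300 nM
Compound 2 `CCOc1cc(-c2ccccc2)ccc1CNc1nc2c(N)ncnc2n1[C@@H]1O[C@H](CO)[C@@H](O)[C@H]1O`: 5400 nM

Both numbers come from an assay on COS-7 cells for inhibition of sodium/nucleoside cotransporter 2 (Homo sapiens), read by scintillation counting; on this read-out higher numbers stand for weaker inhibition and lower numbers for stronger inhibition. Compound 1 holds the lower of the two numbers; compound 2 stands at a higher number, a gap beyond the scatter. Compound 3 `NC(=O)COc1cc(CNc2nc3c(N)ncnc3n2[C@@H]2O[C@H](CO)[C@@H](O)[C@H]2O)ccc1-c1ccccc1` has not been measured. It differs from compound 1 by carbamoyl in place of hydrogen on a saturated chain carbon bound to an oxygen on an aromatic ring. Among the measured compounds shown here, no measured pair shows this change, so the size of the step is open; a move toward a higher number is expected, since the only other variation at this position, compound 2, gives 5400 nM. For compound 3 the expected value is 3000 nM, within 1000 nM to 10000 nM. The step expected is a 2.3-fold higher number from compound 1 to compound 3 (0.36 log units; beyond the scatter).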

Compound 3, half-maximal inhibitory concentration: 5500 nM
The estimate for compound 3 lay 1.8-fold (0.26 log units) below the measured number; measured number inside the range.
By their numbers in this assay, from the lowest: compound 1; then compounds 2 and 3 (each within the scatter of the next).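

In this assay, among the compounds shown here, going from methoxy to carbamoylmethoxy gives the only step read at this position so far (a 4.2-fold higher number from compound 1 to compound 3 (0.63 log units; beyond the scatter)). The position therefore tolerates this larger group with a modest weakening of inhibition, not a complete loss. Nothing at hand explains the size of the step.

On these data alone, it remains open whether the weakening belongs to the carbamoyl group itself or to any extension of the chain. A carboxylic acid, an amine or a longer plain alkyl chain at this position on the core of compound 1 would separate these readings.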